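A few compounds are considered here, and "the series" means these few. Any claim that something is new, unique, unknown or untested is made for them only; others in the source may bear on it.

For the measured compounds named here, compound 3 `CCc1c(Cc2ccccc2Br)nc(SCC(=O)c2ccc(OC)cc2)[nH]c1=O` is the one compound among the three measured that gives a number in an ADME assay on MT4 cells (Homo sapiens) for cytotoxicity; on this read-out higher numbers stand for lower toxicity in this test and lower numbers for higher toxicity in this test: compound 3 gives 187000 nM. For compound 1 `COc1ccc(C(=O)CSc2nc(Cc3ccccc3Br)c(C)c(=O)[nH]2)cc1` the value in this assay is only a limit, > 272000 nM. For compound 2 `COc1ccc(C(=O)CSc2nc(Cc3ccc(Br)cc3)c(C)c(=O)[nH]2)cc1` the value in this assay is likewise only a limit, > 272000 nM. Two of the three values thus sit at the limit of > 272000 nM in this assay, at which 2 of the 3 values shown sit.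

Compound 4 `CCc1c(Cc2cc(C)cc(C)c2)nc(SCC(=O)c2ccc(OC)cc2)[nH]c1=O` differs from compound 3 in one place: 3,5-dimethylphenyl in place of 2-bromophenyl on a saturated chain carbon bound to an aromatic carbon. Going by the values given here, two measured steps bear on this change. The step of an at least 1.4-fold lower number from compound 1 to compound 3 (0.16 log units; that floor lies within the scatter) concerns the group on the saturated chain carbon next in the core and is small. The step that the two limits leave unreadable from compound 1 to compound 2 alters the group on the same saturated chain carbon bound to an aromatic carbon, but both of its ends are limits, so its size cannot be read. Among the compounds with values here, no measured step therefore speaks for a change beyond the scatter. The step expected here is a 1.1-fold higher number from compound 3 to compound 4 (0.03 log units; within the scatter), none beyond the scatter. The estimate for compound 4 in this assay is 200000 nM, within 90000 nM to 400000 nM, with a fair chance that only a limit is reported.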

Compound 4, half-maximal cytotoxic concentration: >= 239000 nM
Compound 4: only a limit was reported; the forecaster's own chance of this, stated with the estimate: 40%; middle value at least 1.1-fold (0.07 log units) from the limit.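

In this assay, replacing 2-bromophenyl with 3,5-dimethylphenyl on the saturated chain carbon gives an at least 1.2-fold higher number from compound 3 to compound 4 (0.10 log units; that floor lies within the scatter). For the compounds shown here, this adds the first change at this place that can be read in direction, though only as a floor, and it shows that the place accepts a phenyl group carrying two methyl groups and no bromine without any fall in the number for compound 4. Even so, compound 4 gives only a limit, so compound 3 remains the only compound here with a true number: the limit of >= 239000 nM in this assay, at which 1 of the 4 values shown sits.

As far as these compounds go, the step from compound 1 to compound 2 cannot be read, and how far the number for compound 4 really lies from that of compound 3 stays open. Also open, from the compounds shown here alone, is what an amine or a carboxylic acid on this phenyl group would do to this read-out.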